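Trimming One Ester Chain on a Calcium Channel Blocker

The source may report more compounds than this note shows. Statements on the series, on what has been measured and on what is new or still open speak of the compounds shown alone.

Of the compounds shown here, three sharing one core have been measured in an assay on ileum for inhibition of Voltage-dependent L-type calcium channel subunit alpha-1C (Cavia porcellus); a higher number here means a weaker inhibitor, a lower number a stronger inhibitor. Compound 1 `CCc1nc(Cl)c(C2C(C(=O)OC)=C(C)NC(C)=C2C(=O)OC)[nH]1` carries two methyl esters and gives 0.596 nM. Compound 2 `CCc1nc(Cl)c(C2C(C(=O)OC)=C(C)NC(C)=C2C(=O)OC(C)C)[nH]1` has one of those esters changed to isopropyl and gives 0.488 nM. Compound 3 `CCc1nc(Cl)c(C2C(C(=O)OC(C)C)=C(C)NC(C)=C2C(=O)OC(C)C)[nH]1` has both esters as isopropyl and gives 0.748 nM. Compound 3 stands at the highest of the three numbers, yet its gaps to compound 1 and to compound 2 both lie within the scatter, so the three cannot be ranked against one another.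

Compound 4 `CCOC(=O)C1=C(C)NC(C)=C(C(=O)OC(C)C)C1c1[nH]c(CC)nc1Cl` differs from compound 3 in a single place: hydrogen in place of methyl on a saturated chain carbon bound to an oxygen next to a carbonyl group and a saturated chain carbon. Cut one bond further out, the same change reads isopropyl to ethyl, or isopropoxycarbonyl to ethoxycarbonyl. Among the compounds with values here, two measured steps bear on it directly, each swapping methyl for isopropyl on one ester oxygen: a 1.2-fold lower number from compound 1 to compound 2 (0.09 log units; within the scatter) and a 1.5-fold higher number from compound 2 to compound 3 (0.19 log units; within the scatter). Shortening isopropyl to ethyl is a smaller move than either of those. Because a 1.2-fold lower number from compound 1 to compound 2 (0.09 log units; within the scatter) and a 1.5-fold higher number from compound 2 to compound 3 (0.19 log units; within the scatter) both stayed within the scatter, no step beyond the scatter is expected in this assay, a 1.2-fold lower number from compound 3 to compound 4 (0.06 log units; within the scatter). Compound 4 is therefore estimated at 0.65 nM, with a range from 0.33 nM to 1.3 nM.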

Compound 4, half-maximal inhibitory concentration: 0.564 nM
Compound 4: middle estimate off by 1.2-fold (0.06 log units), on the high side; measured number inside the range.
By their numbers in this assay, from the lowest: compounds 2, 4, 1 and 3 (each within the scatter of the next).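

With the other ester held as isopropyl, this ester position can now be read across three chains: methyl in compound 2, ethyl in compound 4 and isopropyl in compound 3. In this assay there is a 1.3-fold lower number from compound 3 to compound 4 (0.12 log units; within the scatter) when isopropyl is cut back to ethyl, and there is a 1.2-fold higher number from compound 2 to compound 4 (0.06 log units; within the scatter) when methyl is extended to ethyl, so the ethyl ester cannot be told apart from either of the chains on its two sides, and this position shows no measurable response across these three chains. Nothing available here offers an explanation for that result.

The compounds shown change only the ester chains, all of them methyl, ethyl or isopropyl, so it stays open whether a much longer chain, a benzyl group, or a carboxylic acid in place of the ester would also stay within the scatter of these numbers. It also stays open whether an ethyl ester would read the same with methyl rather than isopropyl on the other ester, since the only ethyl ester shown is paired with isopropyl.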